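This account rests on a few compounds, and the source may have more. Where it says the series, first, only, none or still open, it means among the compounds named here.

Compound 1 `Cc1cc(C)cc(Cn2c(SCC(=O)Nc3ccccc3Cl)nc3ccccc32)c1` and compound 2 `Cc1cc(C)cc(Cn2c(SCC(=O)Nc3ccccc3Cl)nc3ccc(Cl)cc32)c1` share one core and differ in a single place: chloro in place of hydrogen on an aromatic carbon. In an ADME assay on MT4 cells (Homo sapiens) for cytotoxicity (a higher number here means that more compound is tolerated, a lower number that less compound is tolerated), compound 1 gives 111000 nM, and compound 2 gives 141000 nM, so that the step is a 1.3-fold higher number from compound 1 to compound 2 (0.10 log units; within the scatter). Compound 3 `Cc1cc(C)cc(S(=O)(=O)n2c(SCC(=O)Nc3ccccc3[N+](=O)[O-])nc3ccccc32)c1` carries a different core; how it differs from compound 1 is not broken down here. In this assay compound 3 gives only a limit of >= 26000 nM and not a number, as noted in the limit of >= 26000 nM in this assay, at which 1 of the 3 values shown sits. Compound 4 `Cc1cc(C)cc(S(=O)(=O)n2c(SCC(=O)Nc3ccccc3[N+](=O)[O-])nc3ccc(Cl)cc32)c1` has not yet been measured in this assay. It differs from compound 3 by the same change that separates compound 2 from compound 1: chloro in place of hydrogen on an aromatic carbon. For compound 4 the expected step is a step that the limit leaves unreadable from compound 3 to compound 4, resting on the small size of a 1.3-fold higher number from compound 1 to compound 2 (0.10 log units; within the scatter). For compound 4 the estimate in this assay is therefore 40000 nM, with a range from 15000 nM to 150000 nM, and a limit rather than a number is the more likely outcome.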

Compound 4, half-maximal cytotoxic concentration: > 235000 nM
Compound 4: no number, only a limit; the forecaster's own chance of this, stated with the estimate: 60%; at least 5.8-fold (0.76 log units) between middle value and limit.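

For the compounds shown here, compound 3 and compound 4 each give only a limit and not a number in this assay, so no step between them can be read. The compounds shown leave open whether chloro in place of hydrogen on an aromatic carbon stays within the scatter on the core of compound 3, as it does from compound 1 to compound 2.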